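Furan in place of sulfamoylphenyl on the thiazole core

A few compounds are considered here, and "the series" means these few. Any claim that something is new, unique, unknown or untested is made for them only; others in the source may bear on it.

Measured compounds:
compound 1 `O=C(O)Cc1sc(C(c2ccc(F)cc2)c2ccc(F)cc2)nc1-c1ccc(Cl)cc1`, 180 nM
compound 2 `NS(=O)(=O)c1cccc(-c2nc(C(c3ccc(F)cc3)c3ccc(F)cc3)sc2CC(=O)O)c1`, 710 nM

In an in vitro functional assay on HEK285-7 cells for antagonist activity at prostaglandin D2 receptor 2 (Homo sapiens), read by BRET and beta-arrestin recruitment (on this read-out higher numbers stand for weaker inhibition and lower numbers for stronger inhibition), compound 1 gives 180 nM. In this assay compound 2 gives 710 nM, the higher of the two numbers recorded so far; the step of a 3.9-fold higher number from compound 1 to compound 2 (0.60 log units; beyond the scatter) separates them, so compound 2 is the weaker inhibitor of this pair.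

Compound 3 `O=C(O)Cc1sc(C(c2ccc(F)cc2)c2ccc(F)cc2)nc1-c1ccco1` has not yet been measured. It differs from compound 2 in one place: furan-2-yl in place of 3-sulfamoylphenyl on an aromatic carbon. Among the compounds with values here, no measured step covers this exact exchange. Within the data shown here, the only step available, a 3.9-fold higher number from compound 1 to compound 2 (0.60 log units; beyond the scatter), shows that changing the group at this position moves the number by a modest amount only, and that the sulfamoylphenyl of compound 2 gave the higher number. Removing it for the smaller furan-2-yl is therefore expected to give a number no higher than that of compound 2, and probably somewhat lower, yet the expected step of a 1.8-fold lower number from compound 2 to compound 3 (0.25 log units; within the scatter) stays within the scatter. Compound 3 is estimated at 400 nM, with a range from 120 nM to 1500 nM.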

Compound 3, half-maximal inhibitory concentration: 140 nM
Compound 3: the middle estimate sits 2.9-fold (0.46 log units) above what was measured; low and high end bracket the measured number.
By their numbers in this assay, from the lowest: compounds 3 and 1 (each within the scatter of the next); then compound 2.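

In this assay, furan-2-yl in place of 3-sulfamoylphenyl gives a 5.1-fold lower number from compound 2 to compound 3 (0.71 log units; beyond the scatter), a modest step that shows the number at this aromatic carbon, next to the ring nitrogen, can be brought back down by a much smaller group. Furan-2-yl in place of 4-chlorophenyl gives a 1.3-fold lower number from compound 1 to compound 3 (0.11 log units; within the scatter), within the scatter, so the two groups cannot be told apart on this read-out even though they differ in ring size and heavy-atom count. A six-membered aromatic ring of carbon only is therefore not required at this position, and among the three groups shown, only 3-sulfamoylphenyl stands apart, with the higher number.

The compounds shown leave open whether a plain phenyl, a thiophene, a 3-chlorophenyl or a 4-sulfamoylphenyl would sit with the furan-2-yl and 4-chlorophenyl compounds or with compound 2, and so whether the sulfamoyl group itself or its place on the ring sets compound 2 apart. No measurement beyond these numbers bears on what lies behind the result.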